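Aryl swap on nitrogen: compound 3 to compound 4

The source may hold more compounds than are shown below. What is called first, only, known or untested is meant among the compounds shown, and "the series" means these compounds.

Measured in a functional assay on MCF7 cells (Homo sapiens) for inhibition, read by MTT assay, with a stated time of 72 h (a lower number here means a stronger inhibitor, a higher number a weaker inhibitor), as half-maximal inhibitory concentration:
- compound 1 `Cc1cc2occ(-c3nc(-c4ccccc4)c(-c4ccccc4)n3-c3ccc([N+](=O)[O-])cc3)c(=O)c2cc1Cl` at 6250 nM
- compound 2 `Cc1cc2occ(-c3nc(-c4ccccc4)c(-c4ccccc4)n3-c3ccc(Cl)c(Cl)c3)c(=O)c2cc1Cl` at 1560 nM
- compound 3 `Cc1cccc(-n2c(-c3coc4cc(C)c(Cl)cc4c3=O)nc(-c3ccccc3)c2-c2ccccc2)c1` at 12500 nM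

Compound 3 stands at 12500 nM and so lies within the scatter of compound 1 but is clearly weaker than compound 2. Within the data shown here, the change to compound 4 `Cc1ccc(-n2c(-c3coc4cc(C)c(Cl)cc4c3=O)nc(-c3ccccc3)c2-c2ccccc2)c(C)c1` is 2,4-dimethylphenyl in place of 3-methylphenyl on an aromatic nitrogen and no measured compound carries that group. The measured steps at this place are a 2.0-fold higher number from compound 1 to compound 3 (0.30 log units; within the scatter) within the scatter, and the modest 4.0-fold lower number from compound 1 to compound 2 (0.60 log units; beyond the scatter) and an 8.0-fold higher number from compound 2 to compound 3 (0.90 log units; beyond the scatter) which both involve the 3,4-dichlorophenyl of compound 2. That group does not enter here, so no step beyond the scatter is expected in this assay for this change. The estimated change is a 1.3-fold lower number from compound 3 to compound 4 (0.10 log units; within the scatter) on these few data. For compound 4 the estimate is 10000 nM with an expected range of 3500 nM to 25000 nM in this read-out.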

Compound 4, half-maximal inhibitory concentration: 6250 nM
For compound 4 the middle estimate is 1.6-fold (0.20 log units) above the measured one, and the stated range covers the measured number.
By their numbers in this assay, from the lowest: compound 2; then compounds 1, 4 and 3 (each within the scatter of the next).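

In this assay, 2,4-dimethylphenyl in place of 3-methylphenyl gives a 2.0-fold lower number from compound 3 to compound 4 (0.30 log units; within the scatter), and in place of 4-nitrophenyl it gives no change at the digits printed from compound 1 to compound 4 (within the scatter), so this third aryl group also stays within the scatter of the other two. Only the 3,4-dichlorophenyl of compound 2 stands apart, now also with a 4.0-fold higher number from compound 2 to compound 4 (0.60 log units; beyond the scatter). No measurement shown on these compounds explains that gap.

Open, going by these compounds, is whether a 4-chlorophenyl or a 3-chlorophenyl would stay with compound 2 or with the other three. On these data alone, a 4-aminophenyl or a 4-carboxyphenyl on this nitrogen also remains open.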